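The source may hold more compounds than are shown below. What is called first, only, known or untested is meant among the compounds shown, and "the series" means these compounds.

Compound 1 `COc1ccc(N(C)c2ncnc3c2ncn3Cc2cc(OC)c(OC)c(OC)c2)cc1`: in a functional assay on K562 cells (Homo sapiens) for antiproliferative activity, read by MTT assay, with a stated time of 48 h (a lower number here means a stronger inhibitor of growth, a higher number a weaker inhibitor of growth), compound 1 reaches only the limit > 100000 nM.
Compound 2 `COc1ccc(N(C)c2nc(Cl)nc3c2ncn3Cc2cc(OC)c(OC)c(OC)c2)cc1`: in this assay compound 2 gives 41000 nM.
Compound 3 `COc1cc(Cn2cnc3c(Cl)ncnc32)cc(OC)c1`: in this assay compound 3 reaches only the limit > 100000 nM.

For the measured compounds named here, the one measured step, an at least 2.4-fold lower number from compound 1 to compound 2 (0.38 log units; beyond the scatter), comes from the change (chloro in place of hydrogen on an aromatic carbon). The difference between the cores of compound 1 and compound 3 is not broken down here. Compound 4 `COc1cc(Cn2cnc3c(Cl)nc(Cl)nc32)cc(OC)c1` carries the same kind of change on the core of compound 3, (chloro in place of hydrogen on an aromatic carbon), the surroundings differing in that the entering group sits meta to a chloro group rather than meta to a (4-methoxyphenyl)(methyl)amino group. Two of the three values sit at the limit of > 100000 nM in this assay, at which 2 of the 3 values shown sit, so compound 3 offers only a limit to step from. By analogy to an at least 2.4-fold lower number from compound 1 to compound 2 (0.38 log units; beyond the scatter), a step of about an at least 1.6-fold lower number from compound 3 to compound 4 (0.22 log units; that floor lies within the scatter) is expected. Compound 4 is therefore expected near 60000 nM, within 20000 nM to 200000 nM.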

Compound 4, concentration for 50% growth inhibition: 4600 nM
For compound 4 the middle estimate is 13-fold (1.12 log units) above the measured one, outside the stated range (below it).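

On the core of compound 3, chloro in place of hydrogen on an aromatic carbon, between two ring nitrogen atoms, gives an at least 21-fold lower number from compound 3 to compound 4 (1.33 log units; beyond the scatter) in this assay. Set beside the earlier step, the change lowers the number on both cores, so its direction carries over in these two pairs, but nothing firm can be said about whether its size does: the same change on two cores in this assay, an at least 2.4-fold lower number (0.38 log units; beyond the scatter) from compound 1 to compound 2 and an at least 21-fold lower number (1.33 log units; beyond the scatter) from compound 3 to compound 4; the limit leaves it open whether they differ. Both steps start from a compound that reaches only a limit, so neither gives a full size: the limit of > 100000 nM in this assay, at which 2 of the 4 values shown sit.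

The compounds shown leave open what an amine or a bromo group would do in place of this chloro group. They also leave open whether the gain would hold on a third core.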